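The source may report more compounds than this note shows. Statements on the series, on what has been measured and on what is new or still open speak of the compounds shown alone.

Compound 1, `O=C1/C(=C/c2ccc(O)cc2)CCC/C1=C\c1ccc([N+](=O)[O-])cc1`, in a functional assay on HPLF cells (Homo sapiens) for cytotoxicity (a higher number here means that more compound is tolerated, a lower number that less compound is tolerated), reaches only a limit of the assay, > 400000 nM.
Compound 2, `O=C1/C(=C/c2ccc(O)cc2)Cc2ccccc2/C1=C\c1ccc([N+](=O)[O-])cc1`, in this assay gives 75000 nM.
Compound 3, `COc1cc(/C=C2/C(=O)/C(=C/c3ccc([N+](=O)[O-])cc3)c3ccccc32)cc(OC)c1OC`, in this assay reaches only a limit of the assay, > 400000 nM.

For the measured compounds named here, compound 2 thus holds the only actual number among the three; the other two values are limits, as the limit of > 400000 nM in this assay, at which 2 of the 3 values shown sit, shows. Compound 4, `COc1ccc(/C=C2\Cc3ccccc3/C(=C\c3ccc([N+](=O)[O-])cc3)C2=O)cc1OC`, has not yet been measured. It differs from compound 2 in one place: 3,4-dimethoxyphenyl in place of 4-hydroxyphenyl on a double-bonded chain carbon bound to a double-bonded ring carbon. Going by the values given here, no measured pair shows this change, so its effect is open; in this assay a modest rise is expected, toward more compound being tolerated, though it may stay within the usual scatter. Compound 4 is expected to give about 150000 nM, between 40000 nM and 400000 nM. The expected step from compound 2 to compound 4 is a 2.0-fold higher number from compound 2 to compound 4 (0.30 log units; within the scatter).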

Compound 4, half-maximal cytotoxic concentration: > 400000 nM
Compound 4: no number, only a limit; the forecaster's own chance of this, stated with the estimate: 35%; middle value at least 2.6-fold (0.42 log units) from the limit.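

In this assay, the first step read at this position is an at least 5.3-fold higher number from compound 2 to compound 4 (0.72 log units; beyond the scatter), when 3,4-dimethoxyphenyl replaces 4-hydroxyphenyl on a double-bonded chain carbon bound to a double-bonded ring carbon. So this single change moves the tolerated concentration by more than the usual scatter, and upward. Its full size stays unknown, as compound 4 gives only a limit: the limit of > 400000 nM in this assay, at which 3 of the 4 values shown sit.

The compounds shown do not separate losing the hydroxyl group from gaining the two methoxy groups. On these data alone, how a phenyl ring carrying one methoxy group, or an amine, would behave in this place also remains open.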